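Trimethoxyphenyl triazole ketones: cytotoxicity working notes

The source may report more compounds than this note shows. Statements on the series, on what has been measured and on what is new or still open speak of the compounds shown alone.

Measured so far in a functional assay on HepG2 cells (Homo sapiens) for cytotoxicity, read by MTT assay, with a stated time of 48 h; a higher number here means a weaker inhibitor, a lower number a stronger inhibitor:
- compound 1 `Cc1nnc(SCC(=O)c2ccc(Cl)cc2)n1N1C(=O)c2ccccc2C1=O`: compound 1 gives > 200000 nM, which is a limit of the assay, not a number.
- compound 2 `Cc1ccc(C(=O)CSc2nnc(C)n2N2C(=O)c3ccccc3C2=O)cc1`: compound 2 gives > 200000 nM, again a limit of the assay.
- compound 3 `COc1cc(-c2nnc(SCC(=O)c3ccc(Cl)cc3)n2N2C(=O)c3ccccc3C2=O)cc(OC)c1OC`: compound 3 gives 22000 nM, the only number in the set.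

The change from compound 1 to compound 2 is methyl in place of chloro on an aromatic carbon. Its step, a step that the two limits leave unreadable from compound 1 to compound 2, cannot be read because of the limit of > 200000 nM in this assay, at which 2 of the 3 values shown sit. The two cores differ by 3,4,5-trimethoxyphenyl in place of methyl on an aromatic carbon, and that step is an at least 9.0-fold lower number from compound 1 to compound 3 (0.95 log units; beyond the scatter).

Compound 4 `COc1cc(-c2nnc(SCC(=O)c3ccc(C)cc3)n2N2C(=O)c3ccccc3C2=O)cc(OC)c1OC` is not yet measured in this assay. It differs from compound 3 by methyl in place of chloro on an aromatic carbon, the same change as from compound 1 to compound 2, at the same place. Since the earlier step is unreadable, the expectation for compound 4 rests only on compound 3 at 22000 nM, with a step estimated as a 1.6-fold higher number from compound 3 to compound 4 (0.20 log units; within the scatter). Compound 4 is thus expected to give about 35000 nM, somewhere between 8000 nM and 150000 nM.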

Compound 4, half-maximal inhibitory concentration: 9440 nM
For compound 4 the middle estimate is 3.7-fold (0.57 log units) above the measured one, and the stated range covers the measured number.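

On the core of compound 3, methyl in place of chloro gives a 2.3-fold lower number from compound 3 to compound 4 (0.37 log units; beyond the scatter) in this assay, and 3,4,5-trimethoxyphenyl in place of methyl, with the 4-methylphenyl group kept, gives an at least 21-fold lower number from compound 2 to compound 4 (1.32 log units; beyond the scatter). The 3,4,5-trimethoxyphenyl change thus lowers the number on both cores shown, though its size on each is only a bound, and no difference in size between the two cores can be claimed: the same change on two cores in this assay, an at least 9.0-fold lower number (0.95 log units; beyond the scatter) from compound 1 to compound 3 and an at least 21-fold lower number (1.32 log units; beyond the scatter) from compound 2 to compound 4; the limit leaves it open whether they differ The step from chloro to methyl cannot be read on the core of compound 1, so the compounds shown do not tell whether the step seen on the core of compound 3 carries over to another core: the limit of > 200000 nM in this assay, at which 2 of the 4 values shown sit.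

The compounds shown leave open how the number moves with an amine or a nitrile in place of chloro or methyl on the aromatic ring. They also leave open what a carboxylic acid or a longer chain would do in place of the 3,4,5-trimethoxyphenyl group.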